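The source may report more compounds than this note shows. Statements on the series, on what has been measured and on what is new or still open speak of the compounds shown alone.

Three compounds of one family have been examined for cytotoxicity. Compound 1 `Cc1nc(NCCCCNc2ccnc3cc(Cl)ccc23)nc(-c2ccccc2[N+](=O)[O-])c1C(=O)OC(C)C`, compound 2 `CCOC(=O)c1c(C)nc(NCCCNc2ccnc3cc(Cl)ccc23)nc1-c1ccccc1` and compound 3 `Cc1nc(NCCCNc2ccnc3cc(Cl)ccc23)nc(-c2cccc([N+](=O)[O-])c2)c1C(=O)OC(C)C` share a core carrying a chloroquinoline-linked diamine chain. In an ADME assay on Vero cells (Chlorocebus sabaeus) for cytotoxicity, read by microscopy (on this read-out higher numbers stand for lower toxicity in this test and lower numbers for higher toxicity in this test), compound 1 gives 100000 nM, compound 2 gives 100000 nM and compound 3 gives 100000 nM. Compound 2 stands level with compound 1 and compound 3 at the digits reported; the nearest is compound 1 and the furthest compound 3, and neither gap exceeds the scatter of this assay. Compound 4 `CCOC(=O)c1c(C)nc(NCCCNc2ccnc3cc(Cl)ccc23)nc1C` differs from compound 2 by methyl in place of phenyl on an aromatic carbon. For the measured compounds named here, no measured pair shows this change, so the step is open. With all three measured compounds sitting at one value, no shift beyond the scatter is expected in this assay for compound 4, and its estimate is 100000 nM with a range from 50000 nM to 100000 nM, a step of no change at the digits printed from compound 2 to compound 4 (within the scatter).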

Compound 4, minimum cytotoxic concentration: > 100000 nM
Compound 4: only a limit was reported (the forecaster's own chance of this, stated with the estimate: 25%); the middle value lies on the limit itself.
By their numbers in this assay, from the lowest: compounds 1, 2 and 3 (each within the scatter of the next).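

In this assay, replacing phenyl with methyl on this aromatic carbon, ortho to an ethoxycarbonyl group, gives a number no lower from compound 2 to compound 4 (the limit leaves the size open). Compound 4 gives > 100000 nM, which is a limit and not a number: the limit of > 100000 nM in this assay, at which 1 of the 4 values shown sits. The phenyl at this position is therefore not needed to keep the read-out at this level, since the much smaller methyl brings no lower number.

As far as these compounds go, whether an amine or a carboxylic acid on this carbon would lower the number remains open. None of the compounds shown gives a number lower than that of compound 2, so they do not show what would lower it.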